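This account rests on a few compounds, and the source may have more. Where it says the series, first, only, none or still open, it means among the compounds named here.

Of the compounds shown here, two have been measured in an assay on CHO cells for displacement of a labelled ligand from adenosine receptor A3 (Homo sapiens), read by scintillation counting, with a stated time of 45 min, in the presence of a further agent that is not named here; a higher number here means a weaker inhibitor, a lower number a stronger inhibitor. Compound 1 `CCCn1c(=O)[nH]c2nc(-c3ccc(S(=O)(=O)N4CCN(c5ccc(F)cc5)CC4)cc3)[nH]c2c1=O` gives only a limit of the assay, > 1000 nM, and no number. For the measured compounds named here, compound 2 `CCCn1c(=O)[nH]c2nc(-c3ccc(S(=O)(=O)N4CCN(c5cccc(Cl)c5)CC4)cc3)[nH]c2c1=O`, which carries 3-chlorophenyl in place of 4-fluorophenyl on an amine nitrogen in a ring, gives 53.5 nM in this assay and stands as the only numerical value shown. Going by the values given here, the step of an at least 18-fold lower number from compound 1 to compound 2 (1.27 log units; beyond the scatter) is the sole measured step, and its size is read against the starting point the limit of > 1000 nM in this assay, at which 1 of the 2 values shown sits, at which compound 1 sits. Compound 3 `CCCn1c(=O)[nH]c2nc(-c3ccc(S(=O)(=O)N4CCN(Cc5cccc(Br)c5)CC4)cc3)[nH]c2c1=O` differs from compound 2 by 3-bromobenzyl in place of 3-chlorophenyl on an amine nitrogen in a ring. No measured step alters the group on this ring nitrogen in that way; the one step shown says only that the group placed there can move the number a long way. For compound 3 the step from compound 2 is therefore estimated as a 2.8-fold higher number from compound 2 to compound 3 (0.45 log units; beyond the scatter), with broad uncertainty. Compound 3 is expected to give about 150 nM in this assay, within a range from 30 nM to 1000 nM.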

Compound 3, inhibition constant: > 1000 nM
Compound 3 gave a limit, no number (the forecaster's own chance of this, stated with the estimate: 20%); middle value at least 6.6-fold (0.82 log units) away from the limit.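

Putting 3-bromobenzyl in place of 3-chlorophenyl on the amine nitrogen in a ring gives an at least 18-fold higher number from compound 2 to compound 3 (1.27 log units; beyond the scatter) in this assay, so this nitrogen now shows a large loss as well as the large gain seen earlier. Compound 2 is the only one of the three with a number, and neither 4-fluorophenyl in compound 1 nor 3-bromobenzyl in compound 3 matches it, so the number here depends sharply on the group at this position. Compound 1 and compound 3 each give a limit of the assay and not a number, so the step between them cannot be read: the limit of > 1000 nM in this assay, at which 2 of the 3 values shown sit.

The change to compound 3 swaps the halogen and turns the phenyl into a benzyl at once, which leaves open which of the two goes with the step; 3-bromophenyl or 3-chlorobenzyl on this ring nitrogen would separate them. The step from compound 1 to compound 2 is tied up in the same way, since halogen and ring position both change, and 4-chlorophenyl or 3-fluorophenyl would tell these apart.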